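Removing the Trifluoromethyl Group from an Inactive Benzamide

A few compounds are considered here, and "the series" means these few. Any claim that something is new, unique, unknown or untested is made for them only; others in the source may bear on it.

Compound 1 `O=C(Nc1ccc(Cl)c(-c2nnc3c(Cl)cccn23)c1)c1ccc(C(F)(F)F)cc1Cl` is an aryl amide built on a chloro-substituted anilide bearing a bicyclic heteroaromatic group. In a functional assay on T47D cells (Homo sapiens) for antiproliferative activity, read by MTT assay, with a stated time of 72 h (on this read-out lower numbers stand for stronger inhibition and higher numbers for weaker inhibition), compound 1 gives > 100000 nM, which is a limit of the assay rather than a measured number. Two related compounds on the same core were measured as well. Compound 2 `O=C(Nc1ccc(Cl)c(-c2nnc3c(Cl)cccn23)c1)c1ccccc1` gives > 100000 nM in this assay, again a limit. Compound 3 `CS(=O)(=O)c1cccc(C(=O)Nc2ccc(Cl)c(-c3nnc4c(Cl)cccn34)c2)c1` gives > 100000 nM in this assay, once more a limit. For the measured compounds named here, because all three values sit at the limit (the limit of > 100000 nM in this assay, at which 3 of the 3 values shown sit), the step that the two limits leave unreadable from compound 2 to compound 3 cannot be read, and no measured step has a known size.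

Compound 4 `O=C(Nc1ccc(Cl)c(-c2nnc3c(Cl)cccn23)c1)c1ccccc1Cl` differs from compound 1 in one place: hydrogen in place of trifluoromethyl on an aromatic carbon. Going by the values given here, no measured step bears directly on this change, and the only comparison available, the shared limit of > 100000 nM in this assay, at which 3 of the 3 values shown sit, of compounds 1 and 2, gives no sign that a benzamide without trifluoromethyl behaves differently from one with it. The step estimated here is a step that the limit leaves unreadable from compound 1 to compound 4, which is expected to stay within the scatter and most likely to end at the same limit. Compound 4 is therefore expected to give 150000 nM, with a range from 50000 nM to 500000 nM.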

Compound 4, half-maximal inhibitory concentration: 83800 nM
For compound 4 the middle estimate is 1.8-fold (0.25 log units) above the measured one; the range from low to high includes it.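

For the compounds shown here, with hydrogen in place of trifluoromethyl, compound 4 is the only compound here that gives a measured number rather than a limit in this assay, so this position now yields a step with a floor: an at least 1.1-fold lower number from compound 1 to compound 4 (0.07 log units; that floor lies within the scatter). Two further comparisons give the same kind of floor, one for exchanging the whole aryl group on the carbonyl carbon, an at least 1.1-fold lower number from compound 3 to compound 4 (0.07 log units; that floor lies within the scatter), and one for adding chloro to the unsubstituted benzamide, an at least 1.1-fold lower number from compound 2 to compound 4 (0.07 log units; that floor lies within the scatter). None of these floors goes beyond the usual scatter, and the true size of each step stays unknown because the other compound in each pair sits at a limit: the limit of > 100000 nM in this assay, at which 3 of the 4 values shown sit.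

The step from compound 2 to compound 3 still cannot be read, and the compounds shown do not tell whether any other group in the place of trifluoromethyl, such as an amine, a carboxylic acid or a methoxy group, would give a number clearly beyond the scatter from that of compound 4. They also leave open what a group other than chloro, such as fluoro or methyl, would do on that same aromatic ring.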